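This account rests on a few compounds, and the source may have more. Where it says the series, first, only, none or still open, it means among the compounds named here.

Compound 2 has the structure `OCCOCc1c(-c2ccccc2)nc2ccccn12`. In a functional assay on E6SM cells (Homo sapiens) for cytotoxicity (on this read-out lower numbers stand for higher toxicity in this test and higher numbers for lower toxicity in this test), compound 2 gives > 200 ug/mL, which is a limit of the test rather than a number. Two related compounds have been measured beside it. Compound 1, `Cc1ccn2c(COCCO)cnc2c1`, gives > 400 ug/mL in this assay, again a limit. Compound 3, `Cc1ccn2c(CSCCO)cnc2c1`, gives > 200 ug/mL in this assay, also a limit. The values seen so far are therefore only the limit of > 200 ug/mL in this assay, at which 2 of the 3 values shown sit, and (the limit of > 400 ug/mL in this assay, at which 1 of the 3 values shown sits), and no number has been read for any of the three. The change from compound 2 to compound 4 is (2-hydroxyethyl)sulfanyl in place of 2-hydroxyethoxy on a saturated chain carbon bound to an aromatic carbon. The unmeasured compound 4 has the structure `OCCSCc1c(-c2ccccc2)nc2ccccn12`. Going by the values given here, the one measured step that bears on this change is a step that the two limits leave unreadable from compound 1 to compound 3; both of its ends are limits, so its size stays unknown. No step beyond the scatter is expected in either direction, and compound 4 is expected to give about 300 ug/mL, in a range from 150 ug/mL to 800 ug/mL. The expected step from compound 2 to compound 4 is a step that the limit leaves unreadable from compound 2 to compound 4.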

Compound 4, minimum cytotoxic concentration: > 200 ug/mL
Compound 4 gave a limit, no number (the forecaster's own chance of this, stated with the estimate: 85%); the middle value is on the limit's open side.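

Compound 2 and compound 4 both end at a limit of the test rather than a number, so no size can be read for the step between them, and the same holds for compound 1 and compound 3. The compounds shown leave open whether (2-hydroxyethyl)sulfanyl in place of 2-hydroxyethoxy changes toxicity at all.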